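This account rests on a few compounds, and the source may have more. Where it says the series, first, only, none or still open, it means among the compounds named here.

In a functional assay on MM1.S cells (Homo sapiens) for antiproliferative activity, read by luminescence, with a stated time of 72 h (a lower number here means a stronger inhibitor, a higher number a weaker inhibitor), compound 1 `Oc1ccc(Cn2cnc3ccccc32)c2cccnc12` gives 3000 nM and compound 2 `Oc1ccc(Cn2nnc3ccccc32)c2cccnc12` gives 300 nM. Compound 3 `CC(C)(C)OC(=O)Oc1ccc(Cn2ccnc2)c2cccnc12` gives 1800 nM, which lies within the scatter of compound 1 and clearly above compound 2. Compound 4 `CC(C)(CCl)C(=O)Oc1ccc(Cn2ccnc2)c2cccnc12` differs from compound 3 in one place: 1-(chloromethyl)-1-methylethyl in place of tert-butoxy on a carbonyl carbon, with 1-(chloromethyl)-1-methylethyl in place of tert-butoxy on a carbonyl carbon. Within the data shown here, no measured pair shows this exchange, so the data give no direct guide to its effect. With compound 3 at 1800 nM as the closest reference, no change beyond the scatter is expected in this assay, in either direction. The expected step of a 1.2-fold lower number from compound 3 to compound 4 (0.08 log units; within the scatter) is therefore small. Compound 4 is estimated at 1500 nM, with a likely range of 500 nM to 4500 nM.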

Compound 4, half-maximal inhibitory concentration: 3600 nM
Compound 4: the middle estimate sits 2.4-fold (0.38 log units) below what was measured; low and high end bracket the measured number.
By their numbers in this assay, from the lowest: compound 2; then compounds 3, 1 and 4 (each within the scatter of the next).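

In this assay, putting 1-(chloromethyl)-1-methylethyl in place of tert-butoxy on a carbonyl carbon gives a 2.0-fold higher number from compound 3 to compound 4 (0.30 log units; within the scatter). This first exchange read at this position therefore does not separate the two groups, even though the entering group brings chlorine and the leaving group takes away an oxygen. Nothing available explains this result. Still open, from the compounds shown here alone, is whether a smaller group such as methyl, a longer chain or an amine on this carbonyl carbon would give a step beyond the scatter.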